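Swapping the aryl group on a sulfonamide nitrogen

The source may hold more compounds than are shown below. What is called first, only, known or untested is meant among the compounds shown, and "the series" means these compounds.

Two sulfonamide acetamides have been measured in a functional assay on CHO-K1 cells for antagonist activity at prostaglandin E2 receptor EP1 subtype (Homo sapiens), read by FLIPR and calcium flux; on this read-out higher numbers stand for weaker inhibition and lower numbers for stronger inhibition. Compound 1 `CCc1ccccc1N(CC(=O)NCc1ccccc1OC)S(=O)(=O)c1ccc(C)cc1` gives 1070 nM, and compound 2 `Cc1ccc(S(=O)(=O)N(CC(=O)NCc2ccc(Cl)cc2)c2cccnc2C)cc1` gives 676 nM, the lower of the two numbers, although the gap to compound 1 falls within the scatter, so no order between them can be claimed. Compound 3 `CCn1nccc1N(CC(=O)NCc1ccc(Cl)cc1)S(=O)(=O)c1ccc(C)cc1` has not been measured; it differs from compound 2 only in 1-ethyl-1H-pyrazol-5-yl in place of 2-methylpyridin-3-yl on a sulfonamide nitrogen. For the measured compounds named here, no measured pair shows the effect of this change, so compound 3 is expected to stay near compound 2, with a step of a 1.1-fold higher number from compound 2 to compound 3 (0.05 log units; within the scatter), within the scatter. The estimate for compound 3 is 750 nM, between 250 nM and 2300 nM.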

Compound 3, inhibition constant: 72.4 nM
For compound 3 the middle estimate is 10-fold (1.02 log units) above the measured one, and the stated range ends above it.
By their numbers in this assay, from the lowest: compound 3; then compounds 2 and 1 (each within the scatter of the next).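

In this assay, the group on the sulfonamide nitrogen can shift the number beyond the scatter: 1-ethyl-1H-pyrazol-5-yl in place of 2-methylpyridin-3-yl gives a 9.3-fold lower number from compound 2 to compound 3 (0.97 log units; beyond the scatter). The earlier compounds shown here offered no single-place comparison, and here the two groups have the same heavy-atom count. Nothing available accounts for the step.

From the compounds shown here alone, it remains open whether the ethyl chain on the pyrazole matters, as a 1-methyl-1H-pyrazol-5-yl or 1-propyl-1H-pyrazol-5-yl group would show. Going by these compounds, it is equally open whether the step carries over to other amide groups.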